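A few compounds are considered here, and "the series" means these few. Any claim that something is new, unique, unknown or untested is made for them only; others in the source may bear on it.

Series notes. The three measured compounds share one core; compound 1 is `CCCCCN1C(=O)C/C(=C\c2cccc(C(=O)Nc3cccc(CC)c3)c2)C1=O`, compound 2 is `O=C(Nc1cccc(F)c1)c1cccc(/C=C2\CC(=O)N(c3ccccc3)C2=O)c1` and compound 3 is `CCCCCN1C(=O)C/C(=C\c2cccc(C(=O)NCCCC)c2)C1=O`. In an ADME assay on NCM460 cells (Homo sapiens) for cytotoxicity, read by MTT assay, with a stated time of 72 h (a lower number here means a stronger inhibitor, a higher number a weaker inhibitor), compound 1 returns only a limit of the assay, > 100000 nM. Compound 2 in this assay likewise returns a limit, > 100000 nM. Compound 3 in this assay also returns a limit, > 100000 nM. Because all three values rest at the limit of > 100000 nM in this assay, at which 3 of the 3 values shown sit, compound 3 cannot be placed above or below either of the other two; it stands at the ceiling of what was measured, together with them. Among the compounds with values here, the single step between measured compounds that differ in one place, a step that the two limits leave unreadable from compound 1 to compound 3, is unreadable for the same reason, so no size can be attached to an exchange on the amide-type nitrogen.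

The unmeasured compound 4 is `CCCCCN1C(=O)C/C(=C\c2cccc(C(=O)Nc3cccc(F)c3)c2)C1=O`. It differs from compound 3 by 3-fluorophenyl in place of butyl on an amide-type nitrogen. Within the data shown here, no readable step bears on this change; the one measured step at this position gives no size. In this assay no shift beyond the scatter is therefore expected, and the expected step is a step that the limit leaves unreadable from compound 3 to compound 4. Compound 4 is estimated at 150000 nM, with a range from 50000 nM to 500000 nM, most likely reported again as a limit.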

Compound 4, half-maximal inhibitory concentration: > 100000 nM
Compound 4 was reported as a limit; the forecaster's own chance of this, stated with the estimate: 85%; the middle value lies beyond the limit too.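

No new step can be read for compound 4 against compound 1, compound 2 or compound 3 in this assay, because all four values are limits: the limit of > 100000 nM in this assay, at which 4 of the 4 values shown sit. The compounds shown leave open how far any of the four lies from that limit and whether any exchange on the amide-type nitrogen changes the read-out in this assay.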